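This account rests on a few compounds, and the source may have more. Where it says the series, first, only, none or still open, it means among the compounds named here.

Three benzofuroxan or quinoxaline dioxide hydrazones have been measured. In an ADME assay on MRC5 cells (Homo sapiens) for cytotoxicity, read by fluorescence, with a stated time of 24 h (on this read-out lower numbers stand for stronger inhibition and higher numbers for weaker inhibition), compound 1 `Nc1ccccc1C(=O)N/N=C/c1ccc2no[n+]([O-])c2c1` gives 122000 nM, which places it second highest of the three numbers. Compound 3 `N#Cc1c(-c2ccccc2)[n+]([O-])c2ccc(/C=N/NC(=O)c3ccncc3)cc2[n+]1[O-]` sits at 21000 nM in this assay, a gap beyond the scatter, and compound 2 `NC(=O)c1c(COc2cccc(/C=N/NC(=O)c3ccncc3)c2)no[n+]1[O-]` at 1280000 nM, also beyond the scatter. Compound 4 `O=C(N/N=C/c1ccc2no[n+]([O-])c2c1)c1ccccc1` remains to be measured. It differs from compound 1 by hydrogen in place of amino on an aromatic carbon. Among the compounds with values here, no measured pair shows this change, so the size of the step rests on the small extent of the change alone; in this assay no step beyond the scatter is expected, with the estimated step from compound 1 to compound 4 being a 1.1-fold higher number from compound 1 to compound 4 (0.03 log units; within the scatter). Compound 4 is therefore expected to give about 130000 nM, within 50000 nM to 350000 nM.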

Compound 4, half-maximal inhibitory concentration: 130000 nM
Compound 4: the middle estimate sits on the measured number at the digits printed; measured number inside the range.
By their numbers in this assay, from the lowest: compound 3; then compounds 1 and 4 (each within the scatter of the next); then compound 2.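

Within the data shown here, the change from 2-aminophenyl to phenyl gives a 1.1-fold higher number from compound 1 to compound 4 (0.03 log units; within the scatter) in this assay and is the first step that can be read. At this place, on an aromatic carbon ortho to a large group, removing amino leaves the read-out within the scatter for this pair. No available evidence bears on this result. Still open, from the compounds shown here alone, is whether a larger or differently charged group at the same place, such as a carboxylic acid or a methoxy group, would also stay within the scatter.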